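The source may report more compounds than this note shows. Statements on the series, on what has been measured and on what is new or still open speak of the compounds shown alone.

In a functional assay on MDA-MB-231 cells (Homo sapiens) for antiproliferative activity, read by MTT assay, with a stated time of 72 h (a higher number here means a weaker inhibitor, a lower number a stronger inhibitor), compound 1 `O=C(CCc1cccc2c1B(O)OC2)Nc1ccccc1` gives 230 nM, the lowest number among the measured compounds. Compound 2 `C#Cc1ccc(NC(=O)CCc2cccc3c2B(O)OC3)cc1` gives 6600 nM. Compound 3 `CCOC(=O)c1ccc(NC(=O)CCc2cccc3c2B(O)OC3)cc1` reaches only a limit of the assay, > 100000 nM. Compound 4 `O=C(CCc1cccc2c1B(O)OC2)Nc1cccc(-c2ccc(F)cc2)c1` differs from compound 1 by having 4-fluorophenyl in place of hydrogen on an aromatic carbon, meta to a large group (4-fluorophenyl in place of hydrogen on an aromatic carbon). Both measured replacements of hydrogen on an aromatic carbon were large and raised the number, a 29-fold higher number from compound 1 to compound 2 (1.46 log units; beyond the scatter) and an at least 430-fold higher number from compound 1 to compound 3 (2.63 log units; beyond the scatter), so a large step to a higher number, meaning a weaker inhibitor, is expected for compound 4 in this assay. For the measured compounds named here, no measured compound carries 4-fluorophenyl, so the range is wide. The expected change is a 13-fold higher number from compound 1 to compound 4 (1.12 log units; beyond the scatter). Compound 4 is estimated at 3000 nM, with an expected range of 400 nM to 25000 nM.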

Compound 4, half-maximal inhibitory concentration: 250 nM
Beside the measured number, compound 4's estimate is 12-fold (1.08 log units) above it, and the stated range ends above it.
By their numbers in this assay, from the lowest: compounds 1 and 4 (each within the scatter of the next); then compound 2. At a limit, above all of these: compound 3.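

In this assay, placing 4-fluorophenyl on an aromatic carbon, meta to a large group, gives a 1.1-fold higher number from compound 1 to compound 4 (0.04 log units; within the scatter). So adding a group to this ring need not weaken the compound, even one of 7 heavy atoms, although ethynyl in compound 2 and ethoxycarbonyl in compound 3 both gave large steps from compound 1. Nothing available accounts for this contrast. From the compounds shown here alone, whether an amine or a carboxylic acid at this place would also match compound 1 stays open. So does how 4-fluorophenyl would behave elsewhere on the ring.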